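From 3-Hydroxybenzyl to 2-Hydroxybenzyl on the Shared Core

A few compounds are considered here, and "the series" means these few. Any claim that something is new, unique, unknown or untested is made for them only; others in the source may bear on it.

Within the data shown here, in a functional assay (Homo sapiens) for inhibition (on this read-out higher numbers stand for weaker inhibition and lower numbers for stronger inhibition), compound 1 `CSc1ccc(CSc2nc(-c3ccc(F)cc3)c(-c3ccncc3)[nH]2)cc1` gives 670 nM and compound 2 `Oc1cccc(CSc2nc(-c3ccc(F)cc3)c(-c3ccncc3)[nH]2)c1` gives 310 nM, so compound 2 holds the lower of the two numbers so far. Compound 3 `Oc1ccccc1CSc1nc(-c2ccc(F)cc2)c(-c2ccncc2)[nH]1` has the same atoms as compound 2, joined differently: 2-hydroxyphenyl in place of 3-hydroxyphenyl on a saturated chain carbon bound to a sulfur. Among the measured compounds shown here, only one measured step is available as a guide, a 2.2-fold lower number from compound 1 to compound 2 (0.33 log units; beyond the scatter). It is modest, and it exchanges 4-(methylsulfanyl)phenyl for 3-hydroxyphenyl, so it bears on this change only indirectly. For the measured compounds named here, no measured pair compares 3-hydroxyphenyl with 2-hydroxyphenyl. No step beyond the scatter is therefore expected in this assay, with only a slight lean towards a higher number. The expected step is a 1.3-fold higher number from compound 2 to compound 3 (0.11 log units; within the scatter). Compound 3 is estimated at 400 nM, with an expected range of 130 nM to 1200 nM.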

Compound 3, half-maximal inhibitory concentration: 440 nM
Compound 3: the middle estimate sits 1.1-fold (0.04 log units) below what was measured; measured number inside the range.
By their numbers in this assay, from the lowest: compounds 2, 3 and 1 (each within the scatter of the next, the first and the last beyond it).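

In this assay, the 2-hydroxyphenyl in place of the 3-hydroxyphenyl on a saturated chain carbon bound to a sulfur gives a 1.4-fold higher number from compound 2 to compound 3 (0.15 log units; within the scatter), so this pair of isomers cannot be told apart here. The comparison with the 4-(methylsulfanyl)phenyl group also changes: a 1.5-fold lower number from compound 1 to compound 3 (0.18 log units; within the scatter) stays inside the scatter, whereas a 2.2-fold lower number from compound 1 to compound 2 (0.33 log units; beyond the scatter) lay beyond it, so compound 3 goes against any pattern in which both hydroxyphenyl groups stand clearly apart from compound 1. No supporting evidence bears on why these numbers fall as they do.

The compounds shown leave open how 4-hydroxyphenyl, the remaining isomer, would compare in this place. They also leave open whether 3-methoxyphenyl or 3-aminophenyl would stay within the scatter of compound 2.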